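This account rests on a few compounds, and the source may have more. Where it says the series, first, only, none or still open, it means among the compounds named here.

Measured compounds in an assay on HEK293 cells for positive allosteric modulation of metabotropic glutamate receptor 3 (Rattus norvegicus), read by thallium flux, with a stated time of 2.5 min; on this read-out lower numbers stand for smaller maximal responses and higher numbers for larger maximal responses: compound 1 `Cc1c(OCCCCOc2ccc(C(=O)O)cc2F)ccc(C(=O)CC2CCCC2)c1O` gives 31.2%; compound 2 `Cc1c(OCCCCOc2ccc(C(=O)C(C)C)c(O)c2C)cccc1C(=O)O` gives 27.1%; compound 3 `Cc1c(OCCCCOc2ccc(C(=O)O)cc2F)ccc(C(=O)CC(C)C)c1O` gives 67.7%.

Compound 3 stands highest of the three in this assay, with compound 1 nearest and compound 2 furthest below it. For the measured compounds named here, the only step between compounds that differ in one place, a number 36.5 percentage points higher from compound 1 to compound 3 (beyond the scatter), came from isopropyl in place of cyclopentyl on a saturated chain carbon bound to a carbonyl carbon.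

Compound 4 `Cc1c(OCCCCOc2ccccc2C(=O)O)ccc(C(=O)CC(C)C)c1O` differs from compound 3 in another part of the molecule: 2-carboxyphenyl in place of 4-carboxy-2-fluorophenyl on an oxygen on a saturated carbon. Going by the values given here, no measured step bears on this change; the step from compound 1 to compound 3 touched a different position and cannot be carried over. Compound 2, which carries a differently arranged carboxyaryl group, shows a lower number than compound 3, but it also differs elsewhere.

Among the compounds with values here, with no direct precedent, the estimate for compound 4 in this assay is 45%, in the range 20% to 72%, that is an expected step of a number 22.7 percentage points lower from compound 3 to compound 4 (beyond the scatter), downward and beyond the scatter.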

Compound 4, largest response reached (reported as percent of maximum), in percent of the reference or control that the assay uses: 28.1%
Compound 4: the middle estimate sits 16.9 percentage points above what was measured; measured number inside the range.
By their numbers in this assay, from the lowest: compounds 2, 4 and 1 (each within the scatter of the next); then compound 3.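

In this assay, the end of the molecule bearing the carboxylic acid also proves sensitive, not only the group on the chain carbon bound to the carbonyl: 2-carboxyphenyl in place of 4-carboxy-2-fluorophenyl gives a number 39.6 percentage points lower from compound 3 to compound 4 (beyond the scatter). This single change removes the fluorine and rearranges the carboxyl group together, so the compounds cannot assign the step to either alone. Nothing available explains the step. On these data alone, whether chlorine in place of the fluorine, or a tetrazole in place of the carboxylic acid, would keep the higher number remains open.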